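Swapping the Methoxy for a Hydroxyl on the Aryl Ketone

A few compounds are considered here, and "the series" means these few. Any claim that something is new, unique, unknown or untested is made for them only; others in the source may bear on it.

Three compounds share a core in which a ketone carries an aromatic ring. Compound 1 `CN(C)C(=S)SCC(CSC(=S)N(C)C)C(=O)c1ccccc1` bears a plain phenyl ring, and in a functional assay on NCI-H460 cells (Homo sapiens) for inhibition, read by MTT assay, with a stated time of 72 h (a higher number here means a weaker inhibitor, a lower number a stronger inhibitor), compound 1 gives 1930 nM. Compound 2 `COc1ccccc1C(=O)C(CSC(=S)N(C)C)CSC(=S)N(C)C` carries a methoxy group on that ring, and in this assay compound 2 gives 810 nM. Compound 3 `COc1cccc(C(=O)C(CSC(=S)N(C)C)CSC(=S)N(C)C)c1` carries the methoxy at a different place on the ring, and in this assay compound 3 gives 1240 nM. Compound 3 lies close to both others, with a 1.5-fold higher number from compound 2 to compound 3 (0.18 log units; within the scatter) and a 1.6-fold lower number from compound 1 to compound 3 (0.19 log units; within the scatter), so these three cannot be told apart with confidence; only a 2.4-fold lower number from compound 1 to compound 2 (0.38 log units; beyond the scatter) reaches past the noise.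

Compound 4 `CN(C)C(=S)SCC(CSC(=S)N(C)C)C(=O)c1ccc(O)cc1` differs from compound 3 by 4-hydroxyphenyl in place of 3-methoxyphenyl on a carbonyl carbon. Within the data shown here, no measured step covers a hydroxyl group here; the methoxy steps, the nearest guide, were modest or within the scatter. The expected step is therefore a 1.2-fold higher number from compound 3 to compound 4 (0.08 log units; within the scatter), meaning no clear change. Compound 4 is estimated at 1500 nM, with a range from 600 nM to 4000 nM.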

Compound 4, half-maximal inhibitory concentration: 30000 nM
For compound 4 the middle estimate is 20-fold (1.30 log units) below the measured one, and the stated range ends below it.
By their numbers in this assay, from the lowest: compounds 2, 3 and 1 (each within the scatter of the next, the first and the last beyond it); then compound 4.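

The methoxy groups moved the number only modestly or not beyond the scatter, but a hydroxy on the ring gives a 16-fold higher number from compound 1 to compound 4 (1.19 log units; beyond the scatter) in this assay and so shows that this ring does not tolerate every small group. The gap from the methoxy compounds is just as large, with a 24-fold higher number from compound 3 to compound 4 (1.38 log units; beyond the scatter) and a 37-fold higher number from compound 2 to compound 4 (1.57 log units; beyond the scatter) on the carbonyl carbon, and this leaves compound 4 as the weakest of the four. Nothing measured here accounts for this loss. In compound 4 the group and its place on the ring differ from compounds 2 and 3 together, so the effect of the hydroxy cannot be separated from that of its place without a methoxy at the same place or a hydroxy elsewhere on the ring. Going by these compounds, whether an amine or a carboxylic acid at that place would be tolerated also remains open.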